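A few compounds are considered here, and "the series" means these few. Any claim that something is new, unique, unknown or untested is made for them only; others in the source may bear on it.

For the measured compounds named here, compound 1 `CC[C@H]1[C@@H](N)CN1c1c(F)cc2c(=O)c(C(=O)O)cn(C3CC3)c2c1F` is one of three compounds so far examined in a physicochemical assay for solubility, at pH 7.4 (on this read-out lower numbers stand for lower solubility and higher numbers for higher solubility), and compound 1 gives 55.9 ug/mL. Compound 3 `CC1(N)CN(c2nc3c(cc2F)c(=O)c(C(=O)O)cn3C2CC2)C1` gives 13.9 ug/mL in this assay, and compound 2 `C[C@H]1N(c2cc3c(cc2F)c(=O)c(C(=O)O)cn3C2CC2)C[C@]1(C)N` gives 1.3 ug/mL. Among these three numbers compound 1 stands highest: compound 3 is its nearest neighbour and compound 2 its furthest, and both gaps lie beyond the scatter of repeated measurements. Going by the values given here, none of the three pairs differs in only one place, so no single-change step is available as a guide.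

Compound 4 `C[C@@H]1[C@@H](N(C)C)CN1c1c(F)cc2c(=O)c(C(=O)O)cn(C3CC3)c2c1F` differs from compound 1 by a group of 8 heavy atoms (6 carbon, 2 nitrogen; one four-membered non-aromatic ring with 1 hetero atom) in place of a group of 7 heavy atoms (5 carbon, 2 nitrogen; one four-membered non-aromatic ring with 1 hetero atom), on an aromatic carbon. The entering group carries no hydrogen-bond donors where the leaving group carried one; both keep one four-membered non-aromatic ring with one hetero atom and two defined stereocentres.

Among the compounds with values here, with no matching step among the measured compounds, the expectation for compound 4 rests on the spread seen between compound 1 and compounds 2 and 3. The step from compound 1 to compound 4 is expected to run downward, by an amount modestly beyond the scatter, and the expected step of a 2.8-fold lower number from compound 1 to compound 4 (0.45 log units; beyond the scatter) carries a wide uncertainty. Compound 4 is therefore estimated at 20 ug/mL in this assay, with a likely range from 5 ug/mL to 80 ug/mL.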

Compound 4, solubility: 97.1 ug/mL
Beside the measured number, compound 4's estimate is 4.9-fold (0.69 log units) below it; the whole stated range lies below it.
By their numbers in this assay, from the lowest: compound 2; then compound 3; then compounds 1 and 4 (each within the scatter of the next).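

For the compounds shown here, this is the first step in the set that can be read, and in this assay it is small: replacing the group of 7 heavy atoms with the group of 8 heavy atoms, on an aromatic carbon ortho to two fluoro groups, gives a 1.7-fold higher number from compound 1 to compound 4 (0.24 log units; within the scatter). In this one pair, then, a group with 0 hydrogen-bond donors takes the place of a group with 1 hydrogen-bond donor with no difference beyond the scatter, while the four-membered non-aromatic ring and both defined stereocentres stay in place. No measurement among those given bears on why the two compounds read alike.

The step changes the ethyl group to a methyl group and the free amine to a dimethylamino group at the same time, so the compounds shown cannot separate the two changes, and a methylamino group on the same ring would be needed to tell them apart. They also leave open whether the same tolerance would hold for a larger ring at this aromatic carbon, such as a piperazine or a pyrrolidine.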